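Series notes: aryl swap on the exocyclic arm

This account rests on a few compounds, and the source may have more. Where it says the series, first, only, none or still open, it means among the compounds named here.

Two members of this series have been run in a functional assay on NCI-H1975 cells (Homo sapiens) for cytotoxicity, read by CCK-8 assay, with a stated time of 72 h; a higher number here means a weaker inhibitor, a lower number a stronger inhibitor. Compound 1 `C=CCn1c(=O)/c(=C\c2cccc(Cl)c2)[nH]c(=O)/c1=C\c1ccccc1OC` gives 5100 nM in this assay. Compound 2 `C=CCn1c(=O)/c(=C\c2cccc(Br)c2)[nH]c(=O)/c1=C\c1ccccc1OC`, its 3-bromophenyl counterpart, is reported in this assay only as "not active" (no number reported), so no single number marks where compound 2 stands; all that can be said is that compound 1 yielded a measurable value and compound 2 did not.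

Compound 3 `C=CCn1c(=O)/c(=C\c2ccccc2C(F)(F)F)[nH]c(=O)/c1=C\c1ccccc1OC` carries the change (2-(trifluoromethyl)phenyl in place of 3-bromophenyl on a double-bonded chain carbon bound to an aromatic carbon). Among the measured compounds shown here, no measured step connects these two compounds, and the one comparison available, compound 1 against compound 2, offers no number to anchor the size of a move. With compound 2 inactive and compound 1 only weakly active, the expectation for compound 3 in this assay is weak inhibition at best, with a substantial chance that only a limit is reported. Compound 3 is estimated at 10000 nM in this assay, within a range of 2000 nM to 50000 nM.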

Compound 3, half-maximal inhibitory concentration: 14500 nM
The estimate for compound 3 lay 1.5-fold (0.16 log units) below the measured number, within the range that was stated.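

In this assay, the position on a double-bonded chain carbon bound to an aromatic carbon now has a numerical comparison: 2-(trifluoromethyl)phenyl in place of 3-chlorophenyl gives a 2.8-fold higher number from compound 1 to compound 3 (0.45 log units; beyond the scatter), a modest loss of potency beyond the usual scatter. This shows that activity remains measurable with 2-(trifluoromethyl)phenyl at this position, whereas compound 2 has only a "not active" report, so the step from compound 2 to compound 3 cannot be read. No supporting measurement explains the difference between compound 1 and compound 3.

The compounds shown leave open how unsubstituted phenyl would compare with these substituted aryl groups. Also open, from the compounds shown here alone, is how this position would respond to a different type of group, such as a nitrile, an amine or a carboxylic acid on the phenyl ring.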